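A few compounds are considered here, and "the series" means these few. Any claim that something is new, unique, unknown or untested is made for them only; others in the source may bear on it.

Compound 1 `Cc1cn([C@@H]2O[C@H](CO[Si](C)(C)C(C)(C)C)[C@@]3(OS(=O)(=O)C=C3NC(N)=O)[C@H]2O[Si](C)(C)C(C)(C)C)c(=O)n(C)c1=O` and compound 2 `COC(=O)C(=O)CNC1=CS(=O)(=O)O[C@@]12[C@@H](CO[Si](C)(C)C(C)(C)C)O[C@@H](n1cc(C)c(=O)n(C)c1=O)[C@@H]2O[Si](C)(C)C(C)(C)C` share one core and differ only at the amine nitrogen. In a functional assay on HEL cells (Homo sapiens) (a lower number here means that less compound is tolerated, a higher number that more compound is tolerated), compound 1 gives 11000 nM. Compound 2 reaches only a limit of this assay, > 200000 nM. The step of an at least 18-fold higher number from compound 1 to compound 2 (1.25 log units; beyond the scatter) places compound 2 at the most tolerated end of what has been measured. Compound 3 `Cc1cn([C@@H]2O[C@H](CO[Si](C)(C)C(C)(C)C)[C@@]3(OS(=O)(=O)C=C3NCCC(N)=O)[C@H]2O[Si](C)(C)C(C)(C)C)c(=O)n(C)c1=O` follows with carbamoylmethyl in place of (methoxycarbonyl)carbonyl on a saturated chain carbon bound to an amine nitrogen. Among the measured compounds shown here, only that one measured step bears on this change, and the change partly undoes it, so a lower number is expected for compound 3: an at least 6.6-fold lower number from compound 2 to compound 3 (0.82 log units; beyond the scatter). Compound 3 is estimated in this assay at 30000 nM, between 8000 nM and 150000 nM.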

Compound 3, half-maximal cytotoxic concentration: 14800 nM
Compound 3: the middle estimate sits 2.0-fold (0.31 log units) above what was measured; low and high end bracket the measured number.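

In this assay, 2-carbamoylethyl in place of ((methoxycarbonyl)carbonyl)methyl on the amine nitrogen gives an at least 13-fold lower number from compound 2 to compound 3 (1.13 log units; beyond the scatter). 2-Carbamoylethyl in place of carbamoyl gives a 1.3-fold higher number from compound 1 to compound 3 (0.13 log units; within the scatter), so these two amide-bearing groups cannot be told apart here. The high end goes with ((methoxycarbonyl)carbonyl)methyl alone among these compounds, and for compound 2 that end is a limit: the limit of > 200000 nM in this assay, at which 1 of the 3 values shown sits.

On these data alone, it remains open whether the ester or the neighbouring carbonyl of that group matters more. As far as these compounds go, it is also open what a carboxylic acid or an amine at the end of the chain would give.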